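This account rests on a few compounds, and the source may have more. Where it says the series, first, only, none or still open, it means among the compounds named here.

Compound 1 `CCCCNC(=O)NS(=O)(=O)c1ccc(-n2nc(-c3ccccc3)ccc2=O)cc1`: 111%
Compound 2 `CCCCNC(=O)NS(=O)(=O)c1ccc(-n2nc(-c3ccc(C)cc3)ccc2=O)cc1`: 109%
Compound 3 `O=C(NC1CCCCC1)NS(=O)(=O)c1ccc(-n2nc(-c3ccc(Cl)cc3)ccc2=O)cc1`: 114%

All three were tested in a functional assay on the whole organism (blood, strain Wistar albino) for inhibition, with Rattus norvegicus as the target, read by colorimetric assay, with stated times of 15 min and 90 min, at a dose of 20 mg/kg by the oral route; on this read-out higher numbers stand for more inhibition at the one dose given (going by the name of the read-out) and lower numbers for less inhibition. Compound 1 and compound 2 differ by methyl in place of hydrogen on an aromatic carbon, and that change gave a number 2 percentage points lower from compound 1 to compound 2 (within the scatter). Compound 3 and compound 1 share the same kind of scaffold, but the difference between the two cores is not broken down here. Compound 4 `Cc1cc(-c2ccc(=O)n(-c3ccc(S(=O)(=O)NC(=O)NC4CCCCC4)cc3)n2)ccc1Cl`, not yet measured, differs from compound 3 by methyl in place of hydrogen on an aromatic carbon. This is the same kind of change as from compound 1 to compound 2, though not the same: here the methyl enters ortho to a chloro group and meta to a large group, whereas in compound 2 it sits para to a large group. Since the earlier step was a number 2 percentage points lower from compound 1 to compound 2 (within the scatter), the step for compound 4 is expected to be a number 4 percentage points lower from compound 3 to compound 4 (within the scatter). Compound 4 is therefore estimated at 110%, between 96% and 122%.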

Compound 4, a percentage reported as inhibition, in the whole organism at one dose (the size of the read-out at that dose, not a potency): 55.2%
The estimate for compound 4 lay 54.8 percentage points above the measured number; the whole stated range lies above it.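

In this assay, methyl in place of hydrogen on an aromatic carbon gave a number 58.8 percentage points lower from compound 3 to compound 4 (beyond the scatter), so the change did not carry over unchanged from one core to the other: the same change on two cores in this assay, a number 2 percentage points lower (within the scatter) from compound 1 to compound 2 and a number 58.8 percentage points lower (beyond the scatter) from compound 3 to compound 4, 56.8 percentage points apart, beyond the scatter of two such steps. The small step on the core of compound 1 is therefore no safe guide to the same change on the core of compound 3. This does not show what sets the two steps apart: the two pairs differ both in their cores and in where the methyl sits, and one pair per core gives no rule.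

The compounds shown leave open whether the 4-chloro-3-methylphenyl group gives so low a number with butyl in place of the cyclohexyl group. They also leave open whether ethyl or methoxy in place of that methyl does the same.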